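Removing a protecting group and its effect on cell toxicity

A few compounds are considered here, and "the series" means these few. Any claim that something is new, unique, unknown or untested is made for them only; others in the source may bear on it.

Compound 1 `CC(C)(C)OC(=O)NCCCCNCCCN(Cc1ccc(-c2ccccc2)cc1)Cc1ccc(-c2ccccc2)cc1` and compound 2 `NCCCCNCCCN(Cc1ccc(-c2ccccc2)cc1)Cc1ccc(-c2ccccc2)cc1` share one core. In an ADME assay on RAW264.7 cells (Mus musculus) for cytotoxicity, read by resazurin assay, with a stated time of 48 h (on this read-out lower numbers stand for higher toxicity in this test and higher numbers for lower toxicity in this test), compound 1 gives > 100000 nM, which is a limit of the assay rather than a number. Compound 2 gives 4200 nM in this assay. The change between them is hydrogen in place of tert-butoxycarbonyl on an amine nitrogen, and the step is an at least 23-fold lower number from compound 1 to compound 2 (1.37 log units; beyond the scatter); it is known only as a bound because of the limit of > 100000 nM in this assay, at which 2 of the 3 values shown sit.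

Compound 3 `CC(C)(C)OC(=O)NC1CCC(N(CCCN(Cc2ccc(F)cc2)Cc2ccc(F)cc2)CCCN(Cc2ccc(F)cc2)Cc2ccc(F)cc2)CC1` rests on a different core; the difference between the two cores is not broken down here. In this assay compound 3 gives > 100000 nM, again a limit of the assay. Compound 4 `NC1CCC(N(CCCN(Cc2ccc(F)cc2)Cc2ccc(F)cc2)CCCN(Cc2ccc(F)cc2)Cc2ccc(F)cc2)CC1` carries the same kind of change, (hydrogen in place of tert-butoxycarbonyl on an amine nitrogen), but here the amine nitrogen sits on a saturated ring carbon, whereas in compound 1 it sits on a saturated chain carbon.

The step from compound 3 to compound 4 is expected to be an at least 20-fold lower number from compound 3 to compound 4 (1.30 log units; beyond the scatter), resting on the measured drop an at least 23-fold lower number from compound 1 to compound 2 (1.37 log units; beyond the scatter). Compound 4 is therefore estimated at 5000 nM in this assay, expected to fall between 1500 nM and 30000 nM.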

Compound 4, half-maximal cytotoxic concentration: 4500 nM
Estimate against measurement, compound 4: 1.1-fold (0.05 log units) above, within the range that was stated.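

In this assay, hydrogen in place of tert-butoxycarbonyl gives an at least 22-fold lower number from compound 3 to compound 4 (1.34 log units; beyond the scatter), so the large drop seen on the first core also appears on a second core, where the amine nitrogen sits on a saturated ring carbon rather than a saturated chain carbon. Set side by side, the two steps read: the same change on two cores in this assay, an at least 23-fold lower number (1.37 log units; beyond the scatter) from compound 1 to compound 2 and an at least 22-fold lower number (1.34 log units; beyond the scatter) from compound 3 to compound 4; the limit leaves it open whether they differ. On these data alone, the direction of the change therefore carried over from one core to the other, but its exact size on either core remains unknown, and the two sizes cannot be ranked, as the protected compounds are recorded only at a limit of the assay: the limit of > 100000 nM in this assay, at which 2 of the 4 values shown sit.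

The compounds shown have only tert-butoxycarbonyl or hydrogen on this nitrogen, so they leave open how a smaller group, such as acetyl or methyl, would read in this assay. As far as these compounds go, two cores are also a small sample, and it remains open whether the same drop would appear on a third core, for example one with a longer chain.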